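The source may report more compounds than this note shows. Statements on the series, on what has been measured and on what is new or still open speak of the compounds shown alone.

Measured so far:
compound 1, `CC(C)(C)c1ccc(Nc2nc3nonc3nc2O)cc1`: 3900 nM
compound 2, `CCCCc1ccc(Nc2nc3nonc3nc2O)cc1`: 2100 nM

In an assay on mitochondria from L6 cells (Rattus norvegicus) for activation, with a stated time of 90 min (a higher number here means that more compound is needed for the effect, a lower number that less compound is needed), compound 1 gives 3900 nM, and compound 2 gives 2100 nM. The two numbers sit within the scatter of each other, so neither compound can be called the more active; compound 2 simply has the lower of the two numbers. Within the data shown here, the only measured step, a 1.9-fold lower number from compound 1 to compound 2 (0.27 log units; within the scatter), is trifluoromethyl in place of butyl on an aromatic carbon in reverse spirit: it exchanged one four-carbon group for another and moved nothing beyond the scatter.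

Compound 3, `Oc1nc2nonc2nc1Nc1ccc(C(F)(F)F)cc1`, has not yet been measured. It differs from compound 2 in one place: trifluoromethyl in place of butyl on an aromatic carbon. Among the measured compounds shown here, the single step on record exchanged two four-carbon groups, whereas here three fluorines replace three carbons; that step therefore bears on the change only loosely. With no measured guidance pointing either way, compound 3 is expected to give 2500 nM, in the range 800 nM to 8000 nM, a step of a 1.2-fold higher number from compound 2 to compound 3 (0.08 log units; within the scatter) that is expected to stay within the scatter.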

Compound 3, half-maximal effective concentration: 10400 nM
Beside the measured number, compound 3's estimate is 4.2-fold (0.62 log units) below it; the measured number lies above the stated range.
By their numbers in this assay, from the lowest: compounds 2 and 1 (each within the scatter of the next); then compound 3.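

In this assay, the group on this aromatic carbon does affect the number: trifluoromethyl gives a 5.0-fold higher number from compound 2 to compound 3 (0.69 log units; beyond the scatter), and against the other carbon group it gives a 2.7-fold higher number from compound 1 to compound 3 (0.43 log units; beyond the scatter), so more compound is needed in both comparisons. Butyl and tert-butyl could not be told apart, so this is the first change at this position to go beyond the scatter, and it does so although trifluoromethyl and butyl have the same count of heavy atoms. Nothing measured here explains the rise.

The compounds shown compare only three groups at this one position. A longer chain such as hexyl, or a small group such as methyl or a single chlorine atom, could show whether the number follows the carbon chain or responds to fluorine.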